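The compounds below may be only part of what the source reports. "The series", "measured", "known", "first", "only" and "open" are said of these compounds alone.

Going by the values given here, the three compounds measured so far share one core, differing only in the groups hung on its rings. Compound 1 `COc1cc(C(=O)c2cn(-c3cccc([N+](=O)[O-])c3)cc2-c2ccccc2)cc(OC)c1OC` gives 550 nM in a functional assay on MCF7 cells (Homo sapiens) for cytotoxicity, read by MTT assay, with a stated time of 96 h; a lower number here means a stronger inhibitor, a higher number a weaker inhibitor. Compound 2 `COc1cccc(-n2cc(C(=O)c3cc(OC)c(OC)c(OC)c3)c(-c3ccccc3)c2)c1` gives 500 nM in this assay, and the step of a 1.1-fold lower number from compound 1 to compound 2 (0.04 log units; within the scatter) is too small to count. Compound 3 `COc1cc(C(=O)c2cn(-c3ccccc3)cc2-c2ccccc2C)cc(OC)c1OC` gives 190 nM in this assay, the lowest of the three numbers, lying beyond the scatter from both compound 2 and compound 1. Compound 4 `COc1cc(C(=O)c2cn(-c3ccccc3)cc2-c2c(F)cc(F)cc2F)cc(OC)c1OC` has not yet been measured in this assay. Relative to compound 3 it carries 2,4,6-trifluorophenyl in place of 2-methylphenyl on an aromatic carbon. Among the compounds with values here, the only measured step, from compound 1 to compound 2, alters a different ring of the shared core, so no measured step bears on this change. With nothing to guide the direction, the step of a 1.6-fold higher number from compound 3 to compound 4 (0.20 log units; within the scatter) is expected to be small, leaning toward a slightly higher number. Compound 4 is therefore estimated at 300 nM in this assay, with a range from 100 nM to 900 nM.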

Compound 4, half-maximal inhibitory concentration: 180 nM
Estimate against measurement, compound 4: 1.7-fold (0.22 log units) above, and the stated range covers the measured number.
By their numbers in this assay, from the lowest: compounds 4 and 3 (each within the scatter of the next); then compounds 2 and 1 (each within the scatter of the next).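

At this position, on an aromatic carbon of the five-membered aromatic ring with 1 nitrogen, replacing 2-methylphenyl with 2,4,6-trifluorophenyl gives a 1.1-fold lower number from compound 3 to compound 4 (0.02 log units; within the scatter) in this assay. Going by these compounds alone, the earlier step changed a different ring, so this is the first sign that this position can accept two quite differently substituted phenyl rings, one carrying a methyl group and the other three fluorines, with no readable difference in the number. The data shown include no measured property of these groups that could account for this.

The compounds shown leave open whether this position would accept a group carrying an amine or a carboxylic acid on that phenyl ring. They also leave open whether the same swap would read alike with a nitro or methoxy group on the other phenyl ring.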